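Compound 3: trifluoromethoxy at a new ring position

The source may hold more compounds than are shown below. What is called first, only, known or untested is meant among the compounds shown, and "the series" means these compounds.

Among the measured compounds shown here, compound 2 `CCCS(=O)(=O)N1CCN(C2(CNC(=O)c3ccccc3OC(F)(F)F)CCCCC2)CC1` gives 22 nM in an assay on JAR cells for inhibition of sodium- and chloride-dependent glycine transporter 1 (Homo sapiens), read by scintillation proximity assay (a higher number here means a weaker inhibitor, a lower number a stronger inhibitor), the lowest of the two numbers so far; compound 1 `CCCS(=O)(=O)N1CCN(C2(CNC(=O)c3ccccc3C(F)(F)F)CCCCC2)CC1` gives 48.5 nM in this assay. For the measured compounds named here, the single step, a 2.2-fold lower number from compound 1 to compound 2 (0.34 log units; beyond the scatter), concerns trifluoromethoxy in place of trifluoromethyl on an aromatic carbon. Compound 3 `CCCS(=O)(=O)N1CCN(C2(CNC(=O)c3ccc(OC(F)(F)F)cc3)CCCCC2)CC1` differs from compound 2 by 4-(trifluoromethoxy)phenyl in place of 2-(trifluoromethoxy)phenyl on a carbonyl carbon. Going by the values given here, no measured step bears on changing where the trifluoromethoxy group sits on the ring, so the direction is open. For compound 3 a step of a 2.7-fold higher number from compound 2 to compound 3 (0.44 log units; beyond the scatter) is expected, held loosely. Compound 3 is estimated at 60 nM, with a range of 15 nM to 250 nM.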

Compound 3, half-maximal inhibitory concentration: 118 nM
Compound 3: the middle estimate sits 2.0-fold (0.29 log units) below what was measured; measured number inside the range.
By their numbers in this assay, from the lowest: compound 2; then compound 1; then compound 3.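

Moving the group, 4-(trifluoromethoxy)phenyl in place of 2-(trifluoromethoxy)phenyl on a carbonyl carbon, gives a 5.4-fold higher number from compound 2 to compound 3 (0.73 log units; beyond the scatter) with the atoms unchanged, so placement on the ring matters for this group. The advantage of trifluoromethoxy over trifluoromethyl also does not survive this change, since 4-(trifluoromethoxy)phenyl in place of 2-(trifluoromethyl)phenyl gives a 2.4-fold higher number from compound 1 to compound 3 (0.39 log units; beyond the scatter) and the order reverses. Nothing on hand accounts for this loss.

Still open, on these data alone, is how a methoxy group or a chlorine atom on the phenyl ring would compare with trifluoromethoxy, and whether placement matters equally for them.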